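From 4-fluorophenyl to 3-chlorophenyl on the shared core

The compounds below may be only part of what the source reports. "The series", "measured", "known", "first", "only" and "open" are said of these compounds alone.

In a functional assay on HeLa cells (Homo sapiens) for antiproliferative activity, read by sulforhodamine B assay, with a stated time of 48 h (a lower number here means a stronger inhibitor of growth, a higher number a weaker inhibitor of growth), compound 3 `Cc1cc2c(cc1C)C(Cl)=C(c1nnc(-c3ccc(F)cc3)o1)CCC2` gives 6420 nM, which lies within the scatter of compound 1 `Cc1cc2c(cc1C)C(Cl)=C(c1nnc(-c3ccccc3)o1)CCC2` at 4680 nM, while compound 2 `Cc1ccc(-c2nnc(C3=C(Cl)c4cc(C)c(C)cc4CCC3)o2)cc1` gives 679 nM. Compound 4 `Cc1cc2c(cc1C)C(Cl)=C(c1nnc(-c3cccc(Cl)c3)o1)CCC2` carries 3-chlorophenyl in place of 4-fluorophenyl on an aromatic carbon of a five-membered aromatic ring with 2 nitrogen and 1 oxygen (3-chlorophenyl in place of 4-fluorophenyl on an aromatic carbon). Among the compounds with values here, the steps that bear on this change all alter the same phenyl group: fluoro in place of hydrogen gives a 1.4-fold higher number from compound 1 to compound 3 (0.14 log units; within the scatter), methyl in place of hydrogen gives a 6.9-fold lower number from compound 1 to compound 2 (0.84 log units; beyond the scatter), and fluoro in place of methyl gives a 9.5-fold higher number from compound 2 to compound 3 (0.98 log units; beyond the scatter). Within the data shown here, no measured compound holds 3-chlorophenyl, so no step beyond the scatter is expected in this assay, only a slight lean towards a lower number. The estimated step, a 1.8-fold lower number from compound 3 to compound 4 (0.26 log units; within the scatter), stays within the scatter. Compound 4 is estimated at 3500 nM, with an expected range of 1000 nM to 9000 nM.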

Compound 4, concentration for 50% growth inhibition: 5940 nM
The estimate for compound 4 lay 1.7-fold (0.23 log units) below the measured number; low and high end bracket the measured number.
By their numbers in this assay, from the lowest: compound 2; then compounds 1, 4 and 3 (each within the scatter of the next).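

In this assay, 3-chlorophenyl joins the unsubstituted phenyl and 4-fluorophenyl in one group of numbers: the exchange for 4-fluorophenyl stays within the scatter (a 1.1-fold lower number from compound 3 to compound 4 (0.03 log units; within the scatter)), as does chloro in place of hydrogen (a 1.3-fold higher number from compound 1 to compound 4 (0.10 log units; within the scatter)). Within the data shown here, the 4-methylphenyl of compound 2 remains the only phenyl group here that stands apart, now also against 3-chlorophenyl (an 8.7-fold higher number from compound 2 to compound 4 (0.94 log units; beyond the scatter)). Nothing available explains these numbers.

On these data alone, whether an amine or a methoxy group on the phenyl ring would give a number near compound 2 or near compounds 1, 3 and 4 remains open.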